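A few compounds are considered here, and "the series" means these few. Any claim that something is new, unique, unknown or untested is made for them only; others in the source may bear on it.

Measured compounds in a functional assay on CHO cells with adenosine receptor A1 (Homo sapiens) as the target, read by cAMP accumulation and immunoassay, with a stated time of 6 min, tested at 0.1 uM; on this read-out higher numbers stand for a weaker effect at the one concentration tested and lower numbers for a stronger effect:
compound 1 `Nc1scc(CN2CCN(c3ccc(Cl)c(C(F)(F)F)c3)CC2)c1C(=O)c1ccc(Cl)cc1` — -12%
compound 2 `Nc1scc(CN2CCN(C3CCCCCC3)CC2)c1C(=O)c1ccc(Cl)cc1` — 13%

Of the compounds shown here, two have been measured. Among the compounds with values here, compound 2 stands highest of the two numbers in this assay; its nearest neighbour is compound 1, and the only step between measured compounds, a number 25 percentage points higher from compound 1 to compound 2 (beyond the scatter), is beyond the scatter and modest in size.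

Compound 3 `Nc1scc(CN2CCN(c3ccc(F)c(F)c3)CC2)c1C(=O)c1ccc(Cl)cc1` is not yet measured. It differs from compound 2 in one place: 3,4-difluorophenyl in place of cycloheptyl on an amine nitrogen in a ring. Within the data shown here, the change runs opposite to the one measured step in kind, since there a cycloheptyl came in for an aryl group on the amine nitrogen in the ring and the number rose by a number 25 percentage points higher from compound 1 to compound 2 (beyond the scatter); here an aryl group returns in place of cycloheptyl, though not the same aryl group as in compound 1. A drop of a similar, modest size is therefore expected for compound 3, as a number 21 percentage points lower from compound 2 to compound 3 (beyond the scatter). Compound 3 is estimated to give -8% in this assay, within -30% to 15%.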

Compound 3, a percentage reported as activity, at one concentration (the size of the read-out at that concentration, not a potency): -34%
Estimate against measurement, compound 3: 26 percentage points above; the whole stated range lies above it.
By their numbers in this assay, from the lowest: compound 3; then compound 1; then compound 2.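

In this assay, within the data shown here, the return of an aryl group on the amine nitrogen in the ring gives a number 47 percentage points lower from compound 2 to compound 3 (beyond the scatter), a large step that exceeds the one earlier step at this position. The choice of aryl group also counts: 3,4-difluorophenyl in place of 4-chloro-3-(trifluoromethyl)phenyl gives a number 22 percentage points lower from compound 1 to compound 3 (beyond the scatter), so the read-out at this position depends on the groups carried by the phenyl ring as well as on aryl versus cycloheptyl. No available evidence accounts for either step.

Open, on these data alone, is whether an unsubstituted phenyl, a 4-fluorophenyl or a single chlorine on the phenyl ring would fall in line with these two aryl compounds. Also open, as far as these compounds go, is whether a pyridyl or a benzyl group on the same nitrogen would keep the read-out on the aryl side of cycloheptyl.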